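Swapping a Para Substituent on a Weak Inhibitor

The source may hold more compounds than are shown below. What is called first, only, known or untested is meant among the compounds shown, and "the series" means these compounds.

Of the compounds shown here, two built on the same core have been tested in a functional assay on K562 cells (Homo sapiens) for inhibition; on this read-out higher numbers stand for weaker inhibition and lower numbers for stronger inhibition. Compound 1, `O=C1C=CC(OCC(F)(F)F)N1c1cc(Cl)cc(Cl)c1`, gives 1640 nM in this assay. Compound 2, `O=C1C=CC(OCC(F)(F)F)N1c1ccc(C(F)(F)F)cc1`, gives 13100 nM in this assay, which is the highest of the two numbers shown, and the gap between the two compounds lies beyond the usual scatter of repeated measurements; no single-point step is given between them, so only the two values themselves can be compared.

Compound 3, `CC(C)c1ccc(N2C(=O)C=CC2OCC(F)(F)F)cc1`, differs from compound 2 in one place: isopropyl in place of trifluoromethyl on an aromatic carbon. For the measured compounds named here, no measured pair shows what this exchange does in this assay, so the expectation here rests on compound 2 alone. Since the exchange keeps the size of the group at that position roughly similar and adds no hydrogen-bond donors or acceptors, the step from compound 2 to compound 3 is expected to be small, a 1.5-fold lower number from compound 2 to compound 3 (0.16 log units; within the scatter), and quite possibly within the scatter. Compound 3 is therefore expected to give about 9000 nM in this assay, with a likely range from 3000 nM to 30000 nM.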

Compound 3, half-maximal inhibitory concentration: 6620 nM
Beside the measured number, compound 3's estimate is 1.4-fold (0.13 log units) above it, and the stated range covers the measured number.
By their numbers in this assay, from the lowest: compound 1; then compounds 3 and 2 (each within the scatter of the next).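

In this assay, for the compounds shown here, putting isopropyl in place of trifluoromethyl on the aromatic carbon para to a large group gives a 2.0-fold lower number from compound 2 to compound 3 (0.30 log units; within the scatter) and so provides the first measured step at this position. The two groups differ in their atoms, one holding a carbon with three fluorines and the other holding only carbons, yet this read-out does not separate them, since the step does not go beyond the usual variation between repeat measurements. This pair therefore shows that, on this core and for these two groups, the exchange leaves no clear mark on the number, although neither group carries a hydrogen-bond donor or acceptor, so the comparison covers only a narrow kind of change. No separate measurement comes with this pair that could explain the result.

Going by these compounds, whether an amine, a carboxylic acid or a longer alkyl chain at this position would give a number clearly apart from those of compound 2 and compound 3 remains open. On these data alone, it is also open whether the same exchange would give a similarly small step on a ring carrying the two chlorines of compound 1.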